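Swapping the benzyl substituent on a cyanoacrylamide

The source may hold more compounds than are shown below. What is called first, only, known or untested is meant among the compounds shown, and "the series" means these compounds.

Two cyanoacrylamides have been tested in a functional assay on NCI-H460 cells (Homo sapiens) for inhibition, read by MTT assay, with a stated time of 72 h; a lower number here means a stronger inhibitor of growth, a higher number a weaker inhibitor of growth. Compound 1 `COc1ccc(CNC(=O)/C(C#N)=C/c2ccc(Br)o2)cc1` gives 16000 nM. Compound 2 `COc1ccc(CNC(=O)/C(C#N)=C/c2cccc3ccccc23)cc1` gives 15000 nM; the two numbers sit within the usual scatter of each other, so neither can be called the stronger growth inhibitor. Compound 3 `N#C/C(=C\c1cccc2ccccc12)C(=O)NCc1ccc(Cl)c(Cl)c1` has not been measured. It differs from compound 2 by 3,4-dichlorophenyl in place of 4-methoxyphenyl on a saturated chain carbon bound to an amide-type nitrogen. Among the compounds with values here, with only the two compounds above, there is no measured step to guide the change; the expected step in this assay from compound 2 to compound 3 is a 1.5-fold lower number from compound 2 to compound 3 (0.18 log units; within the scatter), which is not beyond the scatter. Compound 3 is therefore estimated at 10000 nM, with a likely range from 3000 nM to 30000 nM.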

Compound 3, concentration for 50% growth inhibition: 7000 nM
Compound 3: the middle estimate sits 1.4-fold (0.15 log units) above what was measured, within the range that was stated.
By their numbers in this assay, from the lowest: compound 3; then compounds 2 and 1 (each within the scatter of the next).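

In this assay, the group on a saturated chain carbon bound to an amide-type nitrogen can change the number: 3,4-dichlorophenyl in place of 4-methoxyphenyl gives a 2.1-fold lower number from compound 2 to compound 3 (0.33 log units; beyond the scatter). This is the first step beyond the scatter among these compounds, though only a modest one. No measurement shown here accounts for the change.

As far as these compounds go, whether a single chlorine would give the same step, and whether the swap carries over to the core of compound 1, stays open. So does the effect of an amine or a carboxylic acid on this ring.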